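Removing the nitro group from a fluorinated analogue

This account rests on a few compounds, and the source may have more. Where it says the series, first, only, none or still open, it means among the compounds named here.

Compound 1, `O=C(O)CCC/C=C\CC1=CCC[C@@H]1NS(=O)(=O)c1ccccc1`: 2300 nM
Compound 2, `O=C(O)CCC/C=C\CC1=CCC[C@@H]1NS(=O)(=O)c1ccccc1[N+](=O)[O-]`: 680 nM
Compound 3, `O=C(O)CC/C=C\C[C@H]1[C@H](F)CC[C@@H]1NS(=O)(=O)c1ccccc1[N+](=O)[O-]`: 560 nM

All three were tested in a functional assay on a cell-free system (plasma) for inhibition of thromboxane A2 receptor (Homo sapiens), read by turbidimetry; on this read-out higher numbers stand for weaker inhibition and lower numbers for stronger inhibition. Compound 2 and compound 1 share a core and differ in one place: hydrogen in place of nitro on an aromatic carbon. That change gave a 3.4-fold higher number from compound 2 to compound 1 (0.53 log units; beyond the scatter). Compound 3 is built on a different core and differs from compound 2 in more than one place; the difference between the two cores is not broken down here. In this assay compound 3 gives a number within the scatter of that of compound 2, so no order between the two is claimed.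

Compound 4, `O=C(O)CC/C=C\C[C@H]1[C@H](F)CC[C@@H]1NS(=O)(=O)c1ccccc1`, has not yet been measured. It differs from compound 3 in the same way that compound 1 differs from compound 2: hydrogen in place of nitro on an aromatic carbon. Because this same change gave a 3.4-fold higher number from compound 2 to compound 1 (0.53 log units; beyond the scatter), compound 4 is expected to show a step of a 3.4-fold higher number from compound 3 to compound 4 (0.53 log units; beyond the scatter). The estimate for compound 4 in this assay is 1900 nM, with a likely range from 800 nM to 4500 nM.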

Compound 4, half-maximal inhibitory concentration: 2000 nM
For compound 4 the middle estimate is 1.1-fold (0.02 log units) below the measured one; the measured number falls inside the stated range.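

In this assay, putting hydrogen in place of the nitro group on the fluorine-bearing core gave a 3.6-fold higher number from compound 3 to compound 4 (0.55 log units; beyond the scatter). Set beside the earlier step on the other core, the change carried over at much the same size: the same change on two cores in this assay, a 3.4-fold higher number (0.53 log units; beyond the scatter) from compound 2 to compound 1 and a 3.6-fold higher number (0.55 log units; beyond the scatter) from compound 3 to compound 4, 1.1-fold (0.02 log units) apart, within the scatter of two such steps. This shows that, in these two pairs, going from 2-nitrophenyl to phenyl gives a matching step on both cores, but two pairs cannot show that it would do so on any further core, and they do not explain why the number rises.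

The compounds shown carry only nitro or hydrogen at this place on the aromatic ring, leaving open whether an amine or a nitrile there would give a number closer to that of the nitro compounds or to that of the hydrogen compounds. Among the compounds shown here, no pair here differs only in the fluorine or only in the chain, and what each of these contributes on its own also stays open.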